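The source may report more compounds than this note shows. Statements on the series, on what has been measured and on what is new or still open speak of the compounds shown alone.

In a functional assay on HepG2 cells (Homo sapiens) for cytotoxicity, read by MTT assay, with a stated time of 72 h (on this read-out lower numbers stand for stronger inhibition and higher numbers for weaker inhibition), the measured compounds gave these values:

Compound 1 `Cc1ccc(-c2nc3cc(NC(=O)CN4CCN(C)CC4)ccc3[nH]2)cc1`: > 50000 nM (a limit)
Compound 2 `CCN1CCN(CC(=O)Nc2ccc3[nH]c(-c4cccn4C)nc3c2)CC1`: > 50000 nM (a limit)
Compound 3 `Cn1cccc1-c1nc2cc(NC(=O)CCl)ccc2[nH]1`: 1800 nM

Compound 1 stands at the limit of > 50000 nM in this assay, at which 2 of the 3 values shown sit, so it offers a limit and no number. Compound 4 `CCN1CCN(CCC(=O)Nc2ccc3[nH]c(-c4ccc(C)cc4)nc3c2)CC1` keeps the core of compound 1 and changes one group: (4-ethylpiperazin-1-yl)methyl in place of 4-methylpiperazin-1-yl on a saturated chain carbon bound to a carbonyl carbon. There, (4-ethylpiperazin-1-yl)methyl takes the place of 4-methylpiperazin-1-yl on a saturated chain carbon bound to a carbonyl carbon.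

For the measured compounds named here, the only measured step at this kind of place is an at least 27-fold lower number from compound 2 to compound 3 (1.44 log units; beyond the scatter), which is large and beyond the scatter. That step puts chloro in place of 4-ethylpiperazin-1-yl, whereas compound 4 keeps the ring. Compound 2 carries 4-ethylpiperazin-1-yl and gives > 50000 nM, again a limit. No step beyond the scatter is therefore expected in this assay, although the limit on compound 1 leaves the true size open. The expected change is a number no higher from compound 1 to compound 4 (the limit leaves the size open). For compound 4, the estimated value is 50000 nM, with an expected range from 15000 nM to 100000 nM.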

Compound 4, half-maximal inhibitory concentration: 14600 nM
For compound 4 the middle estimate is 3.4-fold (0.53 log units) above the measured one; measured number below the stated range.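

In this assay, the change on a saturated chain carbon bound to a carbonyl carbon, from 4-methylpiperazin-1-yl to (4-ethylpiperazin-1-yl)methyl, gives an at least 3.4-fold lower number from compound 1 to compound 4 (0.53 log units; beyond the scatter). For the compounds shown here, earlier, the only number at this kind of place came with chloro in compound 3, at 1800 nM, whereas compound 4 gives a number while keeping a six-membered non-aromatic ring in the group. Compound 1 gives > 50000 nM, which is a limit, so the full size of the step stays open: the limit of > 50000 nM in this assay, at which 2 of the 4 values shown sit.

The step changes the ethyl group and the added methyl link together, so the compounds shown do not say which of the two carries it. Also open, as far as these compounds go, is how (4-methylpiperazin-1-yl)methyl, morpholin-4-ylmethyl or a simple dimethylamino group would read at this place.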